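The source may hold more compounds than are shown below. What is called first, only, known or untested is meant among the compounds shown, and "the series" means these compounds.

Working notes on the nitrile-aziridine urea series.

In a functional assay on WiDr cells (Homo sapiens) for inhibition (a lower number here means a stronger inhibitor, a higher number a weaker inhibitor), compound 2 `N#CC1CN1C(=O)Nc1ccc(F)cc1` gives 2100 nM, the lowest number among the three measured compounds. Compound 1 `N#CC1CN1C(=O)Nc1ccc(Cl)c(Cl)c1` gives 7000 nM in this assay, a number that stands beyond the usual scatter from that of compound 2. Compound 3 `CC(C)(C)NC(=O)N1CC1C#N` gives 180000 nM in this assay, far beyond the scatter from compound 2 and the weakest of the three by a wide margin. The two aryl ureas thus sit well apart from the tert-butyl urea, while the gap between the two aryl ureas is smaller but still outside the scatter.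

Compound 4 `N#CC1CN1C(=O)Nc1ccccc1` has not yet been measured. It differs from compound 2 by hydrogen in place of fluoro on an aromatic carbon. Among the compounds with values here, no pair of measured compounds shows this same change, so there is no measured step to lean on. Given that the number for compound 2 is 2100 nM, the expected step from compound 2 to compound 4 in this assay is a 1.7-fold higher number from compound 2 to compound 4 (0.22 log units; within the scatter), a small move toward a higher number that may not exceed the scatter. Compound 4 is therefore estimated at 3500 nM in this assay, with a range from 1000 nM to 12000 nM.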

Compound 4, half-maximal inhibitory concentration: 5000 nM
Estimate against measurement, compound 4: 1.4-fold (0.15 log units) below; measured number inside the range.
By their numbers in this assay, from the lowest: compound 2; then compounds 4 and 1 (each within the scatter of the next); then compound 3.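

Hydrogen in place of fluoro on an aromatic carbon, para to a group of 8 heavy atoms, gives a 2.4-fold higher number from compound 2 to compound 4 (0.38 log units; beyond the scatter) in this assay, so this one atom has a modest effect on the number, beyond the scatter. Within the data shown here, the earlier compounds included no pair differing in one place, which makes this the first single change that can be read directly. No evidence at hand bears on the reason for this step.

On these data alone, whether other groups at this position, such as methoxy, an amine or a carboxylic acid, would give a lower or a higher number than fluoro or hydrogen remains open. Also open, as far as these compounds go, is whether fluoro elsewhere on the aromatic ring would give a step of similar size, since this single step speaks only for this one position.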